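The source may report more compounds than this note shows. Statements on the series, on what has been measured and on what is new or still open speak of the compounds shown alone.

Compound 1 `O=C(NCc1cc(Cl)ccc1-n1cnnn1)[C@@H]1CC=NN1C(=O)[C@H](O)c1ccccc1` gives < 12 mL.min-1.g-1
Compound 2 `CC1(C[C@@H](O)C(=O)N2N=CC[C@H]2C(=O)NCc2cc(Cl)ccc2-n2cnnn2)CC1` gives < 12 mL.min-1.g-1
Compound 3 `O=C(NCc1cc(Cl)ccc1-n1cnnn1)[C@@H]1C[C@H]2C[C@H]2N1C(=O)[C@H](O)c1ccccc1` gives < 15 mL.min-1.g-1

All three entries are limits of the assay and not numbers.

In an ADME assay on liver for metabolic stability, with Liver microsome (Homo sapiens) as the target, read by LC-MS, using microsomes (a higher number here means faster removal of the compound, a lower number slower removal), compound 2 gives < 12 mL.min-1.g-1 as a limit, so no exact figure exists for it. Compound 2 stands at the limit of < 12 mL.min-1.g-1 in this assay, at which 2 of the 3 values shown sit, and cannot be ranked more finely. Compound 3 stands at the limit of < 15 mL.min-1.g-1 in this assay, at which 1 of the 3 values shown sits, as its own limit.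

Compound 4 `CC(C)CC[C@@H](O)C(=O)N1N=CC[C@H]1C(=O)NCc1cc(Cl)ccc1-n1cnnn1` differs from compound 2 in one place (isobutyl in place of 1-methylcyclopropyl on a saturated chain carbon, two bonds along the chain from a carbonyl carbon and an oxygen on a saturated carbon) with isobutyl in place of 1-methylcyclopropyl on a saturated chain carbon, two bonds along the chain from a carbonyl carbon and an oxygen on a saturated carbon. Cut one bond further out, the same difference reads (1-methylcyclopropyl)methyl to isopentyl.

For the measured compounds named here, the one measured step on this side chain is a step that the two limits leave unreadable from compound 1 to compound 2 with (1-methylcyclopropyl)methyl in place of phenyl, and it offers no size to carry over. With that step unreadable, no step beyond the usual scatter is expected in this assay and no direction can be given. The estimated step is a number no lower from compound 2 to compound 4 (the limit leaves the size open) in size. Compound 4 is expected at 12 mL.min-1.g-1 with an estimated range of 7 mL.min-1.g-1 to 25 mL.min-1.g-1.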

Compound 4, intrinsic clearance in microsomes: 47 mL.min-1.g-1
Compound 4: the middle estimate sits 3.9-fold (0.59 log units) below what was measured; the whole stated range lies below it.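

In this assay, the side chain on this carbon now gives its first readable step: isobutyl in place of 1-methylcyclopropyl, with the same 4 heavy atoms but no ring, gives an at least 3.9-fold higher number from compound 2 to compound 4 (0.59 log units; beyond the scatter). Measured against phenyl on the saturated chain carbon bound to a carbonyl carbon and an oxygen, isopentyl gives an at least 3.9-fold higher number from compound 1 to compound 4 (0.59 log units; beyond the scatter), so the earlier limits had hidden that this position can matter in this assay. Compound 1 and compound 2 each give a limit and not a number, so both steps have a floor and no exact size: the limit of < 12 mL.min-1.g-1 in this assay, at which 2 of the 4 values shown sit.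

Whether the change follows from losing the ring or from another difference between the two groups stays open, and nothing shown tells which part of compound 4 is removed in the microsomes. A plain cyclobutyl group, a shorter chain such as ethyl, or an isopentyl-like chain carrying an ether oxygen would help to separate these possibilities on the same core.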